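Swapping Fluorine for Chlorine on the Outer Ring

The compounds below may be only part of what the source reports. "The series", "measured", "known", "first", "only" and "open" are said of these compounds alone.

Two compounds have been measured in an assay for inhibition of apolipoprotein B-100 (Homo sapiens), tested at 100 nM; a higher number here means a weaker inhibitor, a lower number a stronger inhibitor:
compound 1, `COC(=O)N[C@H]1Cc2ccc(NC(=O)c3cc(C(F)(F)F)ccc3-c3ccc(C(F)(F)F)cc3)cc2C1`, giving 7.5 nM
compound 2, `Cc1cccc(C(=O)Nc2ccc3c(c2)CC(NS(=O)(=O)c2ccccc2)C3)c1-c1ccc(F)cc1`, giving 1.2 nM

Of these two, compound 2 gives the lower number, and its gap to compound 1 lies beyond the usual scatter. Compound 3, `Cc1cccc(C(=O)Nc2ccc3c(c2)CC(NS(=O)(=O)c2ccccc2)C3)c1-c1ccc(Cl)cc1`, is built from compound 2 by one change: chloro in place of fluoro on an aromatic carbon, so that a 4-fluorophenyl becomes a 4-chlorophenyl. Going by the values given here, no two measured compounds differ in just one place, so no step of known size can guide the expectation. Such a swap is expected to shift this assay little, if at all beyond the scatter, in either direction. The expected step from compound 2 to compound 3 is a 1.1-fold higher number from compound 2 to compound 3 (0.03 log units; within the scatter). Compound 3 is therefore estimated at 1.3 nM, within 0.5 nM to 3.5 nM.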

Compound 3, half-maximal inhibitory concentration: 2.4 nM
For compound 3 the middle estimate is 1.8-fold (0.27 log units) below the measured one; measured number inside the range.
By their numbers in this assay, from the lowest: compounds 2 and 3 (each within the scatter of the next); then compound 1.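

In this assay, replacing fluoro with chloro on the outer ring, so that a 4-fluorophenyl becomes a 4-chlorophenyl, gives a 2.0-fold higher number from compound 2 to compound 3 (0.30 log units; within the scatter). Going by these compounds alone, this is the first measured step between two compounds that differ in one place, and it shows that either halogen can sit at this position without a difference that stands out from the scatter. No measurement bears on the reason for this result. Still open, going by these compounds, is how this position responds to a group other than a halogen, such as an amine, a carboxylic acid or a methoxy group.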